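A carbamoyl in place of the aminopropyl chain

This account rests on a few compounds, and the source may have more. Where it says the series, first, only, none or still open, it means among the compounds named here.

Compound 2 `NCCCC[C@H](NC(=O)CN(c1nc(Cl)nc2[nH]cnc12)C1CC1)C(=O)OCc1ccccc1` stands second highest of the three measured compounds in a functional assay on the whole organism (Tail, strain ICR) with Mus musculus as the target, in the tail flick test, with a stated time of 90 min, at a dose of 25 umol/kg by the oral route; a lower number here means a weaker effect, a higher number a stronger effect of the compound at the dose given. Compound 2 gives 35.3%, a number beyond the scatter above compound 3 `O=C(O)C[C@H](NC(=O)CN(c1nc(Cl)nc2[nH]cnc12)C1CC1)C(=O)O`, which gives 25.1%, and well below compound 1 `N=C(N)NCCC[C@H](NC(=O)CN(c1ncnc2c1ncn2C1CCCCO1)C1CC1)C(=O)OCc1ccccc1`, which gives 61.6%. Compound 4 `NC(=O)C[C@H](NC(=O)CN(c1nc(Cl)nc2[nH]cnc12)C1CC1)C(=O)OCc1ccccc1` has not yet been measured in this assay. It differs from compound 2 in one place: carbamoyl in place of 3-aminopropyl on a saturated chain carbon, two bonds along the chain from an amide-type nitrogen and a carbonyl carbon. Among the measured compounds shown here, no measured pair shows this exact change, so the size of the step is open; a moderate fall in this assay seems the likelier direction, though a result within the scatter of compound 2 cannot be excluded. Compound 4 is therefore expected to give about 27%, with a range from 14% to 42%. The step of a number 8.3 percentage points lower from compound 2 to compound 4 (within the scatter) is an estimate, not a measurement.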

Compound 4, a percentage reported as activity, at one dose (the size of the read-out at that dose, not a potency): 32.3%
Compound 4: middle estimate off by 5.3 percentage points, on the low side; the measured number falls inside the stated range.
By their numbers in this assay, from the lowest: compounds 3, 4 and 2 (each within the scatter of the next, the first and the last beyond it); then compound 1.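

In this assay, among the compounds shown here, the step of a number 3 percentage points lower from compound 2 to compound 4 (within the scatter) gives the first comparison here of compounds that differ in one place. It shows that, on this saturated chain carbon, carbamoyl can stand in place of 3-aminopropyl without a result beyond the scatter, so the terminal amine of the 4-aminobutyl chain is not required to keep this read-out at this dose. No measurement at hand speaks to the reason for this result.

From the compounds shown here alone, whether a hydroxymethyl or a plain ethyl group at this position would also stay within the scatter of compound 2 remains open. This single pair also leaves open whether the same change would behave alike on another core.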